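Moving the methyl on the pyridin-3-yl member

A few compounds are considered here, and "the series" means these few. Any claim that something is new, unique, unknown or untested is made for them only; others in the source may bear on it.

Among the measured compounds shown here, in a functional assay on MCF7 cells (Homo sapiens) for inhibition, with a stated time of 96 h (a lower number here means a stronger inhibitor, a higher number a weaker inhibitor), compound 3 `COc1cc(C(=O)c2cn(-c3cccc(C)c3)cc2-c2cccnc2)cc(OC)c1OC` gives 52 nM as the highest of the three numbers so far, beyond the scatter from both other compounds. Compound 1 `COc1cc(C(=O)c2cn(-c3ccc(C)cc3)cc2-c2ccco2)cc(OC)c1OC` gives 22 nM and compound 2 `COc1cc(C(=O)c2cn(-c3ccc(C)cc3)cc2-c2nccs2)cc(OC)c1OC` gives 14 nM in the same test. Compound 4 `COc1cc(C(=O)c2cn(-c3ccc(C)cc3)cc2-c2cccnc2)cc(OC)c1OC` is still unmeasured and has the same atoms as compound 3, joined differently, with 4-methylphenyl in place of 3-methylphenyl on an aromatic nitrogen is the whole difference. For the measured compounds named here, the only measured step, a 1.6-fold lower number from compound 1 to compound 2 (0.20 log units; within the scatter), lies within the scatter and concerns a different group, so no measured step covers this change directly. The indirect evidence is weak. Compound 1 at 22 nM and compound 2 at 14 nM both carry the 4-methylphenyl group, yet neither carries the pyridin-3-yl group, so their gaps to compound 3 cannot be assigned to the methylphenyl change alone. A modest move towards a lower number is therefore expected, with the pyridin-3-yl group kept. The estimated step is a 1.7-fold lower number from compound 3 to compound 4 (0.24 log units; within the scatter) and is expected to stay within the scatter. For compound 4 the estimate is 30 nM with an expected range from 12 nM to 75 nM when measured.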

Compound 4, half-maximal inhibitory concentration: 19 nM
Estimate against measurement, compound 4: 1.6-fold (0.20 log units) above; measured number inside the range.
By their numbers in this assay, from the lowest: compounds 2, 4 and 1 (each within the scatter of the next); then compound 3.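

In this assay, among the compounds shown here, the shift from 3-methylphenyl to 4-methylphenyl on the aromatic nitrogen gives the first direct reading at this position (a 2.7-fold lower number from compound 3 to compound 4 (0.44 log units; beyond the scatter)), and this step lies beyond the scatter although the two groups have the same atoms and the same counts. With 4-methylphenyl held in place, the group on the aromatic carbon gives steps within the scatter (a 1.4-fold higher number from compound 2 to compound 4 (0.13 log units; within the scatter); a 1.2-fold lower number from compound 1 to compound 4 (0.06 log units; within the scatter)), so the numbers do not separate pyridin-3-yl from 1,3-thiazol-2-yl or furan-2-yl, and among the steps in this small set only the change in methylphenyl group lies beyond the scatter. Nothing available here accounts for the difference between the 3-methylphenyl and 4-methylphenyl compounds.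

On these data alone, the comparison of these two methylphenyl groups rests on one pair carrying pyridin-3-yl, so it remains open whether the same gap appears with furan-2-yl or 1,3-thiazol-2-yl on the aromatic carbon. Also open, as far as these compounds go, is how the series would read with an unsubstituted phenyl on the aromatic nitrogen, or with a methoxy group or a carboxylic acid in place of the methyl.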